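From methyl to methoxy on compound 3

The source may hold more compounds than are shown below. What is called first, only, known or untested is meant among the compounds shown, and "the series" means these compounds.

In a functional assay on HepG2 cells (Homo sapiens) for inhibition, read by MTT assay, with a stated time of 48 h (on this read-out higher numbers stand for weaker inhibition of growth and lower numbers for stronger inhibition of growth), compound 1 (`COc1ccc2c(c1)c(C1CC(c3ccc(Cl)cc3)=NN1C(=O)c1ccc(OC)nc1)cn2C`) gives 2080 nM and compound 2 (`COc1cccc(C2=NN(C(=O)c3cccnc3)C(c3cn(C)c4ccc(OC)cc34)C2)c1`) gives 910 nM in this series. Compound 3 (`COc1cccc(C2=NN(C(=O)c3ccc(C)nc3)C(c3cn(C)c4ccc(OC)cc34)C2)c1`) gives 29 nM as the lowest of the three numbers, beyond the scatter from both others.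

The next compound is compound 4 (`COc1cccc(C2=NN(C(=O)c3ccc(OC)nc3)C(c3cn(C)c4ccc(OC)cc34)C2)c1`), with methoxy in place of methyl on an aromatic carbon, next to the ring nitrogen and para to a large group.

For the measured compounds named here, one measured step bears directly on this place. The step of a 31-fold lower number from compound 2 to compound 3 (1.50 log units; beyond the scatter) is large and beyond the scatter, and it comes with methyl in place of hydrogen on an aromatic carbon. It shows that the number can move strongly with a change here, but it says nothing about methoxy. Going by the values given here, no measured pair isolates methyl against methoxy. Compound 1 carries the same (6-methoxypyridin-3-yl)carbonyl, but it differs elsewhere as well and offers no clean comparison.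

Among the compounds with values here, with compound 1 at 2080 nM as the only number for this group, a moderate rise is expected in this assay, smaller than the large measured step. The expected change is a 3.8-fold higher number from compound 3 to compound 4 (0.58 log units; beyond the scatter) in size. For compound 4 the estimate is 110 nM within an expected range of 30 nM to 500 nM on repeat measurement.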

Compound 4, concentration for 50% growth inhibition: 190 nM
Compound 4: the middle estimate sits 1.7-fold (0.24 log units) below what was measured; the range from low to high includes it.
By their numbers in this assay, from the lowest: compound 3; then compound 4; then compound 2; then compound 1.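

In this assay this position separates methyl from methoxy: a 6.6-fold higher number from compound 3 to compound 4 (0.82 log units; beyond the scatter) is a modest step that places 6-methylpyridin-3-yl ahead of 6-methoxypyridin-3-yl. The gain over hydrogen is not confined to methyl, since a 4.8-fold lower number from compound 2 to compound 4 (0.68 log units; beyond the scatter) runs in the same direction as the larger 31-fold lower number from compound 2 to compound 3 (1.50 log units; beyond the scatter) and methoxy keeps part of that gain. For the compounds shown here, with the (6-methoxypyridin-3-yl)carbonyl held constant, an 11-fold lower number from compound 1 to compound 4 (1.04 log units; beyond the scatter) gives a first clean reading at a second place, where 3-methoxyphenyl replaces 4-chlorophenyl in a large step, while nothing available explains any of these steps.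

The compounds shown leave open how an ethyl, a chlorine, a dimethylamino or a trifluoromethyl group at this position would compare with methyl and methoxy, so the two groups mark only two points on this position and no trend. They also leave open whether the step from 4-chlorophenyl to 3-methoxyphenyl would carry over with 6-methylpyridin-3-yl in place, and how other groups on that phenyl ring, such as a fluorine or an amine, would read.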